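The source may report more compounds than this note shows. Statements on the series, on what has been measured and on what is new or still open speak of the compounds shown alone.

Among the measured compounds shown here, compound 2 `Cc1ccc(NC(=O)NCCCOc2cccc(CN3CCCCC3)c2)cc1` gives 631 nM in an assay on isolated protein for inhibition of histamine H2 receptor (Cavia porcellus) (on this read-out higher numbers stand for weaker binding and lower numbers for tighter binding), the highest of the two numbers measured so far. Its nearest neighbour is compound 1 `CC(C)CNC(=O)NCCCOc1cccc(CN2CCCCC2)c1`, which in this assay gives 170 nM. The two differ in a single place, and the step of a 3.7-fold higher number from compound 1 to compound 2 (0.57 log units; beyond the scatter). Compound 3 `CCCCNC(=O)NCCCOc1cccc(CN2CCCCC2)c1` is not yet measured in this assay; set against compound 2 it shows (butyl in place of 4-methylphenyl on an amide-type nitrogen). For the measured compounds named here, the one measured step that bears on this change is the step from compound 1 to compound 2, in which isobutyl, a group with no ring, gave way to 4-methylphenyl with its one six-membered aromatic ring, and the number rose modestly. The change to compound 3 puts a group with no ring back in place of that ring, so the expected step is a 3.2-fold lower number from compound 2 to compound 3 (0.50 log units; beyond the scatter), a modest fall. For compound 3 the estimate in this assay is 200 nM, with a range from 80 nM to 500 nM.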

Compound 3, dissociation constant: 81.3 nM
Compound 3: middle estimate off by 2.5-fold (0.39 log units), on the high side, within the range that was stated.
By their numbers in this assay, from the lowest: compound 3; then compound 1; then compound 2.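

At this amide-type nitrogen, butyl in place of 4-methylphenyl gives a 7.8-fold lower number from compound 2 to compound 3 (0.89 log units; beyond the scatter) in this assay, so a second group with no ring also gives a lower number than the ring-bearing compound 2. The two groups with no ring do not give the same number either: moving from isobutyl to butyl gives a 2.1-fold lower number from compound 1 to compound 3 (0.32 log units; beyond the scatter), a modest step, so the arrangement of the chain at this place matters as well as the absence of a ring. Nothing measured here explains why either step occurs.

From the compounds shown here alone, it remains open whether the higher number of compound 2 goes with the ring itself or with its methyl, a question that a plain phenyl group would address. A longer chain such as hexyl, or a saturated ring such as cyclohexyl, could show how far the trend among these groups extends.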